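Adding a hydroxy group to the benzyl ring of a coumarin amide

The source may report more compounds than this note shows. Statements on the series, on what has been measured and on what is new or still open speak of the compounds shown alone.

Measured compounds:
compound 1 `NC(=O)[C@@H]1CCCN1Cc1cc(=O)oc2cc(OCc3ccccc3)ccc12`, 380 nM
compound 2 `NC(=O)Cc1cc(=O)oc2cc(OCc3ccccc3)ccc12`, 200 nM

In an assay for inhibition of Amine oxidase [flavin-containing] B (Rattus norvegicus) (on this read-out lower numbers stand for stronger inhibition and higher numbers for weaker inhibition), compound 1 gives 380 nM. Compound 2 keeps the same core but carries a plain carbamoyl on the saturated chain carbon, and in this assay compound 2 gives 200 nM. The step of a 1.9-fold lower number from compound 1 to compound 2 (0.28 log units; within the scatter) is within the scatter, so the two compounds cannot be told apart on these numbers; compound 2 simply stands beside compound 1.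

Compound 3 `NC(=O)Cc1cc(=O)oc2cc(OCc3cccc(O)c3)ccc12` keeps compound 2 unchanged except for one place on the benzyl ring: hydroxy in place of hydrogen on an aromatic carbon. Within the data shown here, no measured step touches that ring, so nothing measured here bears on this change. Among the measured compounds shown here, the only step seen, a 1.9-fold lower number from compound 1 to compound 2 (0.28 log units; within the scatter), lies within the scatter, and a change this small is therefore expected to stay within the scatter as well. Compound 3 is expected to give 200 nM, with a range from 70 nM to 600 nM. This estimate means a step of no change at the digits printed from compound 2 to compound 3 (within the scatter), expected to lie within the scatter.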

Compound 3, half-maximal inhibitory concentration: 1000 nM
Estimate against measurement, compound 3: 5.0-fold (0.70 log units) below, outside the stated range (above it).
By their numbers in this assay, from the lowest: compounds 2 and 1 (each within the scatter of the next); then compound 3.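

This position on the benzyl ring is not a neutral place for a change: in this assay, hydroxy in place of hydrogen gives a 5.0-fold higher number from compound 2 to compound 3 (0.70 log units; beyond the scatter) and so weakens inhibition. The earlier step, made on the saturated chain carbon, could not be told apart from the scatter, whereas this one, on an aromatic carbon meta to a large group, can. No measurement here explains why the added hydroxy has this effect.

Still open, going by these compounds, is whether the loss belongs to hydroxy itself or would also follow from another group in the same place, such as methoxy or fluorine. On these data alone, it is also open whether the same hydroxy would weaken inhibition to a similar extent on compound 1, which carries the 2-carbamoylpyrrolidin-1-yl group.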